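The source may hold more compounds than are shown below. What is called first, only, known or untested is meant among the compounds shown, and "the series" means these compounds.

Three measured compounds share a core and differ in the group attached to it. Compound 1 `Nc1cccc(/C=C/c2ccccc2O)c1` carries an amino group, compound 2 `COc1cccc(/C=C/c2ccccc2O)c1` a methoxy group, and compound 3 `COc1ccc(/C=C/c2ccccc2O)cc1` has the same atoms as compound 2, joined differently. In a functional assay on HT-29 cells (Homo sapiens) for inhibition, read by MTT assay, with a stated time of 2 days (a lower number here means a stronger inhibitor, a higher number a weaker inhibitor), compound 1 gives 30.4 ug/mL, compound 2 gives 26 ug/mL, and compound 3 gives 10 ug/mL. The difference between the cores of compound 2 and compound 3 is not broken down here; their values show compound 3 with the lower number, a gap beyond the usual scatter, and compound 3 also stands below compound 1 by more than the scatter.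

From compound 2 to compound 1 the change is amino in place of methoxy on an aromatic carbon. In this assay it made a 1.2-fold higher number from compound 2 to compound 1 (0.07 log units; within the scatter), a step within the scatter of repeated measurements.

Compound 4 `Nc1ccc(/C=C/c2ccccc2O)cc1` has not yet been measured. It arises from compound 3 by amino in place of methoxy on an aromatic carbon. This is the same kind of change as from compound 2 to compound 1, but the place differs: there the group sat meta to a group of 9 heavy atoms, here it sits para to a group of 9 heavy atoms. Because a 1.2-fold higher number from compound 2 to compound 1 (0.07 log units; within the scatter) stayed within the scatter, compound 4 is expected to move only a little from compound 3. For compound 4 the expected step is a 1.2-fold higher number from compound 3 to compound 4 (0.08 log units; within the scatter). In this assay compound 4 is estimated at 12 ug/mL, likely between 6 ug/mL and 24 ug/mL.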

Compound 4, half-maximal inhibitory concentration: 37 ug/mL
Compound 4: middle estimate off by 3.1-fold (0.49 log units), on the low side, and the stated range ends below it.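

In this assay, putting amino in place of methoxy on the core of compound 3 made a 3.7-fold higher number from compound 3 to compound 4 (0.57 log units; beyond the scatter), a modest step but a clear one. Set beside the earlier case, the same swap did not carry over from one core to the other with the same size: the same change on two cores in this assay, a 1.2-fold higher number (0.07 log units; within the scatter) from compound 2 to compound 1 and a 3.7-fold higher number (0.57 log units; beyond the scatter) from compound 3 to compound 4, 3.2-fold (0.50 log units) apart, beyond the scatter of two such steps. Among the compounds shown here, this shows that a step measured on one core cannot simply be copied onto the other, but with only two pairs it does not show why the steps differ, nor what the swap would do on any further core, and the place of the group is the only difference between the two cores that can be seen here.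

The compounds shown hold only methoxy and amino at these two places, so it remains open whether another group there, such as a fluorine, a methyl or a dimethylamino group, would give a small step or a larger one. As far as these compounds go, it also remains open how the same swap would behave on a core in which the hydroxyl group is replaced by a methoxy group.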